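The source may report more compounds than this note shows. Statements on the series, on what has been measured and on what is new or still open speak of the compounds shown alone.

Measured in a functional assay on HL-60 cells (Homo sapiens) for cytotoxicity, read by MTT assay, with a stated time of 24 h; on this read-out lower numbers stand for stronger inhibition and higher numbers for weaker inhibition:
- compound 1 `CN1CCN(CCCCCOc2c(Br)cc(Br)cc2Oc2ccc(Br)cc2Br)CC1`: 48.3 ug/mL
- compound 2 `OCCCOc1c(Br)cc(Br)cc1Oc1ccc(Br)cc1Br`: 29.9 ug/mL
- compound 3 `CCOC(=O)C(C)Oc1c(Br)cc(Br)cc1Oc1ccc(Br)cc1Br`: 35.7 ug/mL

Compound 3, at 35.7 ug/mL, lies within the scatter of both compound 1 and compound 2, so the three numbers give no ranking in this assay.

Next is compound 4 `BrCCCCCOc1c(Br)cc(Br)cc1Oc1ccc(Br)cc1Br`, not yet measured. The change is 5-bromopentyl in place of 1-(ethoxycarbonyl)ethyl on an oxygen on an aromatic ring.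

For the measured compounds named here, two measured steps bear on this. The closer one, a 1.2-fold higher number from compound 2 to compound 3 (0.08 log units; within the scatter), also exchanges the group on an oxygen on an aromatic ring. The other, a 1.6-fold lower number from compound 1 to compound 2 (0.21 log units; within the scatter), alters a saturated chain. Going by the values given here, no measured compound carries 5-bromopentyl, so direct precedent is lacking, and the small steps so far give no direction.

The expected result is a 1.0-fold lower number from compound 3 to compound 4 (0.01 log units; within the scatter), with no shift beyond the scatter anticipated. The estimate for compound 4 is 35 ug/mL, with an expected range of 17 ug/mL to 70 ug/mL.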

Compound 4, half-maximal inhibitory concentration: 25.7 ug/mL
Compound 4: middle estimate off by 1.4-fold (0.13 log units), on the high side; measured number inside the range.
By their numbers in this assay, from the lowest: compounds 4, 2, 3 and 1 (each within the scatter of the next).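

In this assay, 5-bromopentyl in place of 1-(ethoxycarbonyl)ethyl on an oxygen on an aromatic ring gives a 1.4-fold lower number from compound 3 to compound 4 (0.14 log units; within the scatter), so a number of this size does not depend on the ester at this position. The bromo-ended chain also stays level with the other two chain ends, with a 1.2-fold lower number from compound 2 to compound 4 (0.07 log units; within the scatter) against hydroxy and a 1.9-fold lower number from compound 1 to compound 4 (0.27 log units; within the scatter) against 4-methylpiperazin-1-yl, so hydroxy, ester, bromo and piperazine ends are not told apart here. Nothing available gives a reason for these numbers.

From the compounds shown here alone, whether a carboxylic acid or a chain longer than 5-bromopentyl on this oxygen would move the number beyond the scatter remains open. Also open, going by these compounds, is whether changes to the shared core would do so, since all four compounds carry it unchanged.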